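Aryl amides and a sulfonamide on the shared core

The source may report more compounds than this note shows. Statements on the series, on what has been measured and on what is new or still open speak of the compounds shown alone.

Measured so far in a functional assay on HL-60 cells (Homo sapiens) for antiproliferative activity, read by MTT assay, with a stated time of 72 h; on this read-out lower numbers stand for stronger inhibition and higher numbers for weaker inhibition:
compound 1 `CCC(=O)N(C)c1ccc2[nH]c(-c3n[nH]c4ccccc34)cc2n1` gives 6130 nM
compound 2 `CN(C(=O)c1ccc(Cl)cc1)c1ccc2[nH]c(-c3n[nH]c4ccccc34)cc2n1` gives 450 nM
compound 3 `CN(C(=O)c1ccco1)c1ccc2[nH]c(-c3n[nH]c4ccccc34)cc2n1` gives 4540 nM

Compound 1 stands at the highest of the three numbers. Compound 3 lies nearest to it, and a 1.4-fold lower number from compound 1 to compound 3 (0.13 log units; within the scatter), so the furan-2-yl amide and the propanoyl amide are not separable here. Compound 2 lies furthest: a 14-fold lower number from compound 1 to compound 2 (1.13 log units; beyond the scatter), and in the reverse direction a 10-fold higher number from compound 2 to compound 3 (1.00 log units; beyond the scatter).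

Compound 4 `Cc1ccc(S(=O)(=O)N(C)c2ccc3[nH]c(-c4n[nH]c5ccccc45)cc3n2)cc1` is not yet measured in this assay. Its change from compound 1: (4-methylphenyl)sulfonyl in place of propanoyl on a nitrogen on an aromatic ring. Going by the values given here, the one measured step that bears on it is the entry of an aromatic ring on the carbonyl carbon in compound 2, which gave a 14-fold lower number from compound 1 to compound 2 (1.13 log units; beyond the scatter); compound 3 shows that a ring of a different kind gave nothing beyond the scatter. Among the compounds with values here, no measured step touches the change from a carbonyl to a sulfonyl on the nitrogen, so the carry-over from compound 2 is uncertain. A lower number than compound 1 is expected, with a step of about a 4.1-fold lower number from compound 1 to compound 4 (0.61 log units; beyond the scatter), smaller than that to compound 2. Compound 4 is estimated at 1500 nM, in the range 400 nM to 5500 nM.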

Compound 4, half-maximal inhibitory concentration: 3030 nM
The estimate for compound 4 lay 2.0-fold (0.31 log units) below the measured number, and the stated range covers the measured number.
By their numbers in this assay, from the lowest: compound 2; then compounds 4, 3 and 1 (each within the scatter of the next, the first and the last beyond it).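

Carrying a sulfonyl on the nitrogen in place of a carbonyl does not abolish activity in this assay, and compound 4 improves modestly on the propanoyl amide (a 2.0-fold lower number from compound 1 to compound 4 (0.31 log units; beyond the scatter)). This sulfonamide cannot be separated from the furan-2-yl amide (a 1.5-fold lower number from compound 3 to compound 4 (0.18 log units; within the scatter)), but it falls well short of the 4-chlorophenyl amide (a 6.7-fold higher number from compound 2 to compound 4 (0.83 log units; beyond the scatter)). A six-membered aromatic ring at this position therefore does not by itself reproduce the number of compound 2, though compounds 2 and 4 differ in both the linking group and the ring substituent.

Still open, going by these compounds, is which of those two differences matters, a question that the 4-methylphenyl amide and the 4-chlorophenyl sulfonamide would settle. The series also leaves open how a morpholine or a benzyl group would fare at this position.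

No measurement here explains these differences.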